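The compounds below may be only part of what the source reports. "The series", "measured", "known", "first", "only" and "open" are said of these compounds alone.

Working notes on the series. In a functional assay on the whole organism (Tail, strain ICR) with Mus musculus as the target, in the tail flick test, with a stated time of 120 min, at a dose of 25 umol/kg by the oral route (a higher number here means a stronger effect of the compound at the dose given, a lower number a weaker effect), compound 1 `C[C@H](NC(=O)CN(c1nc(Cl)nc2[nH]cnc12)C1CC1)C(=O)O` gives 28.4%. Compound 2 `CC(C)[C@H](NC(=O)CN(c1ncnc2c1ncn2C1CCCCO1)C1CC1)C(=O)OCc1ccccc1` gives 25.8% in this assay, and compound 3 `C[C@H](NC(=O)CN(c1nc(Cl)nc2[nH]cnc12)C1CC1)C(=O)OCc1ccccc1` gives 36.1%. Compound 1 stands second highest of the three numbers shown; its nearest neighbour is compound 2 and its furthest is compound 3, and both gaps lie within the scatter. Among the compounds with values here, the single one-place step measured so far, a number 7.7 percentage points higher from compound 1 to compound 3 (within the scatter), is itself within the scatter.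

Compound 4 `O=C(CN(c1nc(Cl)nc2[nH]cnc12)C1CC1)N[C@@H](CO)C(=O)O` has not yet been measured in this assay. It differs from compound 1 by hydroxy in place of hydrogen on a saturated chain carbon, two bonds along the chain from an amide-type nitrogen and a carbonyl carbon. Within the data shown here, no measured step touches this place: the step from compound 1 to compound 3 concerns the benzyl and says nothing about a hydroxy on the saturated chain carbon. With nothing pointing either way and all three measured values lying within the scatter of one another, the step is expected to be a number 0.4 percentage points lower from compound 1 to compound 4 (within the scatter). For compound 4 the expected value in this assay is estimated at 28%, with a range from 14% to 42%.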

Compound 4, a percentage reported as activity, at one dose (the size of the read-out at that dose, not a potency): 39%
Estimate against measurement, compound 4: 11 percentage points below; low and high end bracket the measured number.
By their numbers in this assay, from the lowest: compounds 2, 1, 3 and 4 (each within the scatter of the next, the first and the last beyond it).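

In this assay, within the data shown here, the change from methyl to hydroxymethyl, a number 10.6 percentage points higher from compound 1 to compound 4 (beyond the scatter) and modest in size, is the first one-place step to pass beyond the scatter. This marks the saturated chain carbon as a place where one added hydroxy can shift the read-out at this dose, something the benzyl step, a number 7.7 percentage points higher from compound 1 to compound 3 (within the scatter) on its own, did not show for its position. Nothing at hand gives a reason for the step.

As far as these compounds go, it remains open whether the step depends on the hydroxy itself, as an amine, a methoxy or a longer chain such as 2-hydroxyethyl on the same carbon would begin to show. From the compounds shown here alone, it is also open whether hydroxymethyl gives a similar step when paired with the benzyl ester of compound 3.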